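A few compounds are considered here, and "the series" means these few. Any claim that something is new, unique, unknown or untested is made for them only; others in the source may bear on it.

In an ADME assay on L929 cells (Mus musculus) for cytotoxicity, read by resazurin assay, with a stated time of 48 h (a higher number here means that more compound is tolerated, a lower number that less compound is tolerated), compound 1 (`O=C(O)CCn1c2ccc([N+](=O)[O-])cc2c(=O)n1Cc1ccccc1`) gives > 256000 nM as a limit of the assay and not a number. Compound 2 (`CNC(=O)CCCn1c2ccc([N+](=O)[O-])cc2c(=O)n1Cc1ccccc1`) gives > 256000 nM as a limit too. Compound 3 (`O=c1c2cc([N+](=O)[O-])ccc2n(CCO)n1Cc1ccccc1`) likewise stands at > 256000 nM as a limit and not a number. All three readings sit together (the limit of > 256000 nM in this assay, at which 3 of the 3 values shown sit) with no number among them. Compound 4 (`CCOC(=O)n1c2ccc([N+](=O)[O-])cc2c(=O)n1Cc1ccccc1`) carries ethoxycarbonyl in place of 2-hydroxyethyl on an aromatic nitrogen. The measured steps that changed the chain on that nitrogen (a step that the two limits leave unreadable from compound 1 to compound 2; a step that the two limits leave unreadable from compound 1 to compound 3; a step that the two limits leave unreadable from compound 2 to compound 3) have no readable size, so no step beyond the usual scatter is expected in this assay for compound 4, although a lower value remains possible. The estimated step (an at least 1.2-fold lower number from compound 3 to compound 4 (0.10 log units; that floor lies within the scatter)) is therefore small. Compound 4 is estimated at 200000 nM within an expected range from 70000 nM to 256000 nM in this measurement.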

Compound 4, concentration lethal to 50% of the cells: 122000 nM
Compound 4: middle estimate off by 1.6-fold (0.21 log units), on the high side, within the range that was stated.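

The steps among compound 1, compound 2 and compound 3 cannot be read, but ethoxycarbonyl on this aromatic nitrogen gives the position its first readable change: an at least 2.0-fold lower number from compound 3 to compound 4 (0.32 log units; beyond the scatter) and an at least 2.0-fold lower number from compound 2 to compound 4 (0.32 log units; beyond the scatter) and also an at least 2.0-fold lower number from compound 1 to compound 4 (0.32 log units; beyond the scatter) on the same nitrogen. These sizes are only floors, since compound 4 alone carries a number: the limit of > 256000 nM in this assay, at which 3 of the 4 values shown sit. From the compounds shown here alone, the true size of each step stays open. So does whether an acetyl group or a 2-aminoethyl chain on this nitrogen would also lower the number.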